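Working notes: propargyl to (furan-2-yl)methyl on the shared core

A few compounds are considered here, and "the series" means these few. Any claim that something is new, unique, unknown or untested is made for them only; others in the source may bear on it.

- Compound 1 `C#CCn1nnc2c(C(N)=O)ncn2c1=O`: 35600 nM
- Compound 2 `COc1ccc(Cn2nnc3c(C(N)=O)ncn3c2=O)c(OC)c1`: > 50000 nM

Among the compounds with values here, in a functional assay on SNB-19 cells (Homo sapiens) for inhibition, read by MTT assay, with a stated time of 7 days (on this read-out lower numbers stand for stronger inhibition of growth and higher numbers for weaker inhibition of growth), compound 1 gives 35600 nM, the only actual number so far. Compound 2 reports > 50000 nM, which is a limit of the assay and not a number. Compound 3 `NC(=O)c1ncn2c(=O)n(Cc3ccco3)nnc12` carries furan-2-yl in place of ethynyl on a saturated chain carbon bound to an aromatic nitrogen. Within the data shown here, no measured step is available to size this change. In this assay no step beyond the scatter is expected, though any drift would be expected toward weaker inhibition of growth. The expected change is a 1.3-fold higher number from compound 1 to compound 3 (0.10 log units; within the scatter). Compound 3 is estimated at 45000 nM, with an expected range of 20000 nM to 80000 nM.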

Compound 3, concentration for 50% growth inhibition: > 50000 nM
Compound 3: no number, only a limit; the forecaster's own chance of this, stated with the estimate: 45%; middle value at least 1.1-fold (0.04 log units) from the limit.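

In this assay, furan-2-yl in place of ethynyl on a saturated chain carbon bound to an aromatic nitrogen gives an at least 1.4-fold higher number from compound 1 to compound 3 (0.14 log units; that floor lies within the scatter). Compound 3 reports > 50000 nM, which is a limit of the assay and not a number. The step therefore has only a floor, and the furan-2-yl change cannot be sized further: the limit of > 50000 nM in this assay, at which 2 of the 3 values shown sit.

Open, as far as these compounds go, is whether any other group at this place gives a clearly lower number than compound 1. An amine or a carboxylic acid on the chain in place of ethynyl would address this.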